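Swapping the aryl group on a diaryl urea

The source may hold more compounds than are shown below. What is called first, only, known or untested is meant among the compounds shown, and "the series" means these compounds.

Two diaryl ureas built on the same core have been measured. Compound 1 `Cc1ccc(NC(=O)Nc2ccc(Oc3ccc(-c4nccs4)cc3)cc2)cc1` carries a 4-methylphenyl group and a thiazole ring; compound 2 `O=C(Nc1ccc(Oc2ccc(-c3ncc[nH]3)cc2)cc1)Nc1ccc(Cl)c([N+](=O)[O-])c1` carries a 4-chloro-3-nitrophenyl group and an imidazole ring. In a functional assay on MDA-MB-231 cells (Homo sapiens) for inhibition, read by MTT assay and WST assay, with a stated time of 72 h, tested at 10 uM (on this read-out lower numbers stand for less inhibition of growth and higher numbers for more inhibition of growth at the one concentration tested), compound 1 gives 22.8%, while compound 2 gives 3.36%, the lower of the two numbers. These two compounds differ in two places at once, so their gap cannot be tied to a single change.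

Compound 3 `Cc1ccc(NC(=O)Nc2ccc(Oc3ccc(-c4ncc[nH]4)cc3)cc2)cc1` differs from compound 2 in one place only: 4-methylphenyl in place of 4-chloro-3-nitrophenyl on an amide-type nitrogen. Because compound 1, which shares this 4-methylphenyl group, gives 22.8%, compound 3 is expected to come out higher than compound 2 by a modest margin, a step of a number 10.6 percentage points higher from compound 2 to compound 3 (beyond the scatter) that may or may not exceed the scatter. The estimate for compound 3 is 14%, within a range from 0% to 32%.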

Compound 3, percent growth inhibition at one concentration: 49.3%
Estimate against measurement, compound 3: 35.3 percentage points below; the whole stated range lies below it.
By their numbers in this assay, from the lowest: compound 2; then compound 1; then compound 3.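

In this assay, 4-methylphenyl in place of 4-chloro-3-nitrophenyl on the amide-type nitrogen gives a number 45.9 percentage points higher from compound 2 to compound 3 (beyond the scatter) and shows that this one position can shift growth inhibition by a large amount. With 4-methylphenyl kept fixed, 1H-imidazol-2-yl in place of 1,3-thiazol-2-yl on an aromatic carbon gives a number 26.5 percentage points higher from compound 1 to compound 3 (beyond the scatter) and shows that this second place also counts, so the two changes mixed in the earlier comparison can now be read separately. Nothing available here measures a property that would explain either step.

The compounds shown leave open whether the higher number comes from gaining the methyl group or from losing the chlorine and nitro groups, which a plain phenyl or a 4-chlorophenyl group at the same nitrogen could help separate. They also leave open whether 1H-imidazol-2-yl would compare the same way with 1,3-thiazol-2-yl when 4-chloro-3-nitrophenyl is present.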